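Indolyl-thioether pyrimidine ureas: amine replacement at the ring

The compounds below may be only part of what the source reports. "The series", "measured", "known", "first", "only" and "open" are said of these compounds alone.

Of the compounds shown here, two have numbers so far. Compound 1 `Cc1cc(Cl)ccc1NC(=O)Nc1nc(NC2CC2)cc(Sc2c[nH]c3ccccc23)n1` gives 11100 nM in a functional assay on PC-3 cells (Homo sapiens) for inhibition, with a stated time of 72 h; on this read-out lower numbers stand for stronger inhibition and higher numbers for weaker inhibition. Compound 2 `COc1ccc(NC(=O)Nc2nc(Sc3c[nH]c4ccccc34)cc(N3CCCCC3)n2)cc1` gives 17400 nM in this assay, the higher of the two numbers, though its gap to compound 1 lies within the scatter of repeated measurements, so no order between them can be read. Going by the values given here, the two differ in more than one place, so no single step between them is counted.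

Compound 3 `COc1ccc(NC(=O)Nc2nc(Nc3cc(OC)cc(OC)c3)cc(Sc3c[nH]c4ccccc34)n2)cc1` is not yet measured. It differs from compound 2 as follows: (3,5-dimethoxyphenyl)amino in place of piperidin-1-yl on an aromatic carbon. Among the compounds with values here, no measured step of this kind exists, so nothing beyond the scatter can be asserted for it. The expectation for compound 3 is a number near that of compound 2, possibly somewhat lower, giving an estimated step of a 2.2-fold lower number from compound 2 to compound 3 (0.34 log units; beyond the scatter) in this assay. Compound 3 is estimated at 8000 nM, with a range from 2500 nM to 25000 nM.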

Compound 3, half-maximal inhibitory concentration: 15100 nM
Compound 3: middle estimate off by 1.9-fold (0.28 log units), on the low side; low and high end bracket the measured number.
By their numbers in this assay, from the lowest: compounds 1, 3 and 2 (each within the scatter of the next).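

On the aromatic carbon next to the ring nitrogen, (3,5-dimethoxyphenyl)amino in place of piperidin-1-yl gives a 1.2-fold lower number from compound 2 to compound 3 (0.06 log units; within the scatter) in this assay. Going by these compounds alone, this is the first step that changes only this position, and it leaves the two compounds indistinguishable, even though the entering group has more heavy atoms, an aromatic ring instead of a non-aromatic one, and a hydrogen-bond donor. No available evidence bears on this result.

Going by these compounds, it remains open whether morpholin-4-yl or a longer chain such as n-butylamino on this carbon would give a step beyond the scatter. On these data alone, it is also open whether this replacement would read the same alongside the urea aryl group of compound 1, since a single step covers only one background.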